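The source may hold more compounds than are shown below. What is called first, only, known or untested is meant among the compounds shown, and "the series" means these compounds.

Compound 2 `O=C(CCCCCCc1ccccc1)c1ncno1` carries a five-membered aromatic ring on the carbonyl of a phenyl-capped chain. In an assay on isolated protein for inhibition of neutral cholesterol ester hydrolase 1 (Homo sapiens) (a higher number here means a weaker inhibitor, a lower number a stronger inhibitor), compound 2 gives 25000 nM, the lowest of the two numbers shown. Compound 3 `O=C(CCCCCCc1ccccc1)c1nc(-c2ccccn2)no1` gives 30000 nM, and the step of a 1.2-fold higher number from compound 2 to compound 3 (0.08 log units; within the scatter) changes nothing beyond the scatter. Compound 1 `COC(=O)c1cccc(-c2nnc(C(=O)CCCCCCc3ccccc3)o2)n1` yields only a limit, > 100000 nM, which is the limit of > 100000 nM in this assay, at which 1 of the 3 values shown sits. Compound 4 `O=C(CCCCCCc1ccccc1)c1nnn[nH]1` differs from compound 2 by 1H-tetrazol-5-yl in place of 1,2,4-oxadiazol-5-yl on a carbonyl carbon. Among the measured compounds shown here, no measured step swaps the ring itself; the single measured step concerns another place and was within the scatter, so no shift beyond the scatter is expected. Compound 4 is therefore estimated at 25000 nM, between 8000 nM and 80000 nM. This expectation amounts to a step of no change at the digits printed from compound 2 to compound 4 (within the scatter).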

Compound 4, half-maximal inhibitory concentration: 60000 nM
Beside the measured number, compound 4's estimate is 2.4-fold (0.38 log units) below it; low and high end bracket the measured number.
By their numbers in this assay, from the lowest: compounds 2, 3 and 4 (each within the scatter of the next, the first and the last beyond it). At a limit, above all of these: compound 1.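

Swapping 1,2,4-oxadiazol-5-yl for 1H-tetrazol-5-yl on the carbonyl carbon gives a 2.4-fold higher number from compound 2 to compound 4 (0.38 log units; beyond the scatter) in this assay and is a modest step. It is the first step shown that changes the ring itself, and the first to pass the scatter, so this position responds to the identity of the ring. Nothing shown explains this shift.

On these data alone, whether other groups on this carbonyl carbon, such as a carboxylic acid or a thiazole ring, would give lower numbers stays open. So does the effect of a shorter chain.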